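Methoxy on the Sulfonyl Pyridine: Expected Whole-Animal Inhibition

The source may report more compounds than this note shows. Statements on the series, on what has been measured and on what is new or still open speak of the compounds shown alone.

Compound 1 `CNCc1cn(S(=O)(=O)c2cccs2)c(-c2cccnc2F)c1F`: 98%
Compound 2 `CNCc1cn(S(=O)(=O)c2ccoc2)c(-c2cccnc2F)c1F`: 95%
Compound 3 `CNCc1cn(S(=O)(=O)c2ccccn2)c(-c2cccnc2F)c1F`: 95%

In a functional assay on the whole organism (strain Jcl:Sprague-Dawley) for inhibition, with Rattus norvegicus as the target, with stated times of 3 min and 3 h, at a dose of 1 mg/kg by the intravenous route (on this read-out higher numbers stand for more inhibition at the one dose given (going by the name of the read-out) and lower numbers for less inhibition), compound 3 gives 95%, level with compound 2 and within the scatter of compound 1; the three numbers are alike. Compound 4 `CNCc1cn(S(=O)(=O)c2cccc(OC)n2)c(-c2cccnc2F)c1F` differs from compound 3 by methoxy in place of hydrogen on an aromatic carbon. Going by the values given here, no measured step adds or removes a group on the ring attached to the sulfonyl sulfur; the closest steps swap that whole ring, a number 3 percentage points lower from compound 1 to compound 3 (within the scatter) and no change at the digits printed from compound 2 to compound 3 (within the scatter), both within the scatter. Those swaps changed little, so only a small shift is expected in this assay for compound 4: a number 2 percentage points lower from compound 3 to compound 4 (within the scatter). Compound 4 is therefore estimated at 93%, with a range from 75% to 99%.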

Compound 4, a percentage reported as inhibition, in the whole organism at one dose (the size of the read-out at that dose, not a potency): 98%
Estimate against measurement, compound 4: 5 percentage points below; the range from low to high includes it.
By their numbers in this assay, from the lowest: compounds 2, 3, 1 and 4 (each within the scatter of the next).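

In this assay, going by these compounds alone, methoxy on an aromatic carbon next to the ring nitrogen is the first group added to the ring on the sulfonyl sulfur, not a swap of the whole ring, and it costs nothing measurable: a number 3 percentage points higher from compound 3 to compound 4 (within the scatter) is the step. The same holds against the other rings, with a number 3 percentage points higher from compound 2 to compound 4 (within the scatter) and no change at the digits printed from compound 1 to compound 4 (within the scatter) as the steps. Nothing measured explains why this carbon accepts methoxy. Open, going by these compounds, is whether an amine, a carboxylic acid or a longer chain such as butoxy would fare alike here. Also open, on these data alone, is whether methoxy on another carbon of this ring would.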